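Swapping Cyclohexyl for Benzyl on Compound 1

The compounds below may be only part of what the source reports. "The series", "measured", "known", "first", "only" and "open" are said of these compounds alone.

Compound 1 `O=Cc1ccc(-c2cn3ccnc3c(-c3ccc4ncn(C5CCCCC5)c4c3)n2)cc1` has the lowest of the three numbers in a functional assay on PC-3 cells (Homo sapiens) for inhibition, read by sulforhodamine B assay, with a stated time of 48 h, tested at 10 uM; on this read-out higher numbers stand for more inhibition at the one concentration tested (going by the name of the read-out) and lower numbers for less inhibition: compound 1 gives 19%. Compound 3 `Clc1ccc(-c2cn3ccnc3c(-c3ccc4ncn(C5CCCCC5)c4c3)n2)cc1` gives 24.6%, and the step of a number 5.6 percentage points higher from compound 1 to compound 3 (within the scatter) lies within the scatter. Compound 2 `c1ccc2c(-c3cn4ccnc4c(-c4ccc5ncn(C6CCCCC6)c5c4)n3)cccc2c1` gives 36.5%, the step of a number 17.5 percentage points higher from compound 1 to compound 2 (beyond the scatter) reaching beyond it. Compound 4 `O=Cc1ccc(-c2cn3ccnc3c(-c3ccc4ncn(Cc5ccccc5)c4c3)n2)cc1` differs from compound 1 in one place: benzyl in place of cyclohexyl on an aromatic nitrogen. Among the compounds with values here, none of the measured steps touches the group on the aromatic nitrogen; all three concern the aryl group on the aromatic carbon, so none bears directly on this change. With nothing to guide the direction, a step beyond the scatter is not expected, and the estimated step of a number 3 percentage points higher from compound 1 to compound 4 (within the scatter) stays within it. Compound 4 is therefore expected to give 22%, with a range from 5% to 40%.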

Compound 4, a percentage reported as inhibition, at one concentration (the size of the read-out at that concentration, not a potency): 19%
Compound 4: middle estimate off by 3 percentage points, on the high side; the measured number falls inside the stated range.
By their numbers in this assay, from the lowest: compounds 1, 4 and 3 (each within the scatter of the next); then compound 2.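

Placing benzyl in place of cyclohexyl on the aromatic nitrogen gives no change at the digits printed from compound 1 to compound 4 (within the scatter) in this assay, the only step shown at this position. For this pair, with the 4-formylphenyl group held fixed, an aromatic ring carried through one extra carbon reads the same as the non-aromatic ring attached directly. No measurement at hand gives a reason for this result. The compounds shown leave open whether the same swap reads alike with the naphthalen-1-yl or 4-chlorophenyl groups in place. They also leave open how methyl, a longer chain ending in an amine, or a carboxylic acid on this nitrogen would read.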